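This account rests on a few compounds, and the source may have more. Where it says the series, first, only, none or still open, it means among the compounds named here.

For the measured compounds named here, in a functional assay on A2780 cells (Homo sapiens) for cytotoxicity, read by MTT assay, with a stated time of 72 h (a lower number here means a stronger inhibitor, a higher number a weaker inhibitor), compound 1 `Cc1cc(C)cc(C(=O)N(CC(=O)NCc2ccccc2)Cc2ccc(C(=O)Nc3cc(F)ccc3N)cc2)c1` gives 5400 nM, the lower of the two numbers so far. Compound 2 `Cc1cc(C)cc(C(=O)N(CCCCCC(=O)Nc2ccccc2N)CC(=O)NCc2ccccc2)c1` gives 20900 nM, a gap beyond the scatter, although the two differ in more than one place. Compound 3 `Cc1cc(C)cc(C(=O)N(CC(=O)NCc2ccccc2)Cc2ccc(C(=O)Nc3ccccc3N)cc2)c1` departs from compound 1 by a single change, hydrogen in place of fluoro on an aromatic carbon, taking 2-amino-5-fluorophenyl to 2-aminophenyl. Going by the values given here, no measured pair isolates this change. In this assay, the estimated step of a 1.1-fold higher number from compound 1 to compound 3 (0.05 log units; within the scatter) is expected to stay within the scatter, with neither direction favoured. Compound 3 is expected at 6000 nM, within an estimated range of 2500 nM to 14000 nM.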

Compound 3, half-maximal inhibitory concentration: 2800 nM
Beside the measured number, compound 3's estimate is 2.1-fold (0.33 log units) above it, and the stated range covers the measured number.
By their numbers in this assay, from the lowest: compounds 3 and 1 (each within the scatter of the next); then compound 2.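

In this assay, for the compounds shown here, the single change of hydrogen in place of fluoro on the aromatic carbon para to the amino group gives a 1.9-fold lower number from compound 1 to compound 3 (0.29 log units; within the scatter). Going by these compounds alone, this is the first step that isolates one change, and it shows that 2-amino-5-fluorophenyl and 2-aminophenyl read alike here, so the fluoro is not required at this level of cytotoxicity. No measurement at hand bears on the reason for this. On these data alone, whether a larger group on this carbon, such as methoxy or trifluoromethyl, also reads alike remains open. So does the outcome of the same change on the core of compound 2.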